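This account rests on a few compounds, and the source may have more. Where it says the series, first, only, none or still open, it means among the compounds named here.

Compound 1 `C/N=C(/S)[C@@]1(c2cccnc2)CCCC[C@@H]1C/C=C/c1ccccc1` and compound 2 `C/N=C(/S)[C@@]1(c2cccnc2)CCCC[C@@H]1C/C=C/c1ccc(F)cc1` share one core, and compound 3 `C/N=C(/S)[C@@]1(c2cccnc2)CCCC[C@@H]1CCNC(=O)c1ccccc1` and compound 4 `C/N=C(/S)[C@@]1(c2cccnc2)CCCC[C@@H]1CCNC(=O)c1ccc(F)cc1` share another; the difference between the two cores is not broken down here. In a functional assay (aorta) with Rattus norvegicus as the target (a lower number here means a stronger inhibitor, a higher number a weaker inhibitor), compound 1 gives 100 nM, compound 2 gives 10 nM, and compound 3 gives 300 nM. Within the first pair the only change is fluoro in place of hydrogen on an aromatic carbon, and it brought a 10-fold lower number from compound 1 to compound 2 (1.00 log units; beyond the scatter). Compound 4 has not been measured; it differs from compound 3 by fluoro in place of hydrogen on an aromatic carbon, the same change at the same kind of place as in the first pair. The expectation for compound 4 rests on the step from compound 1 to compound 2, since that is the only measured case of this change here. Compound 4 is expected to show a step of a 6.0-fold lower number from compound 3 to compound 4 (0.78 log units; beyond the scatter) in this assay, taken from the earlier step but allowed to be somewhat smaller; the two cores differ in ways that are not broken down. Compound 4 is therefore estimated at 50 nM in this assay, with a likely range from 10 nM to 300 nM.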

Compound 4, concentration for 90% inhibition: 500 nM
Estimate against measurement, compound 4: 10-fold (1.00 log units) below; the whole stated range lies below it.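

In this assay, changing phenyl to 4-fluorophenyl on the core of compound 3 gives a 1.7-fold higher number from compound 3 to compound 4 (0.22 log units; within the scatter), so compound 3 and compound 4 cannot be told apart, and the gain seen on the core of compound 1 does not appear here. The effect of this change therefore did not carry over from one core to the other in this series: the same change on two cores in this assay, a 10-fold lower number (1.00 log units; beyond the scatter) from compound 1 to compound 2 and a 1.7-fold higher number (0.22 log units; within the scatter) from compound 3 to compound 4, 17-fold (1.22 log units) apart, beyond the scatter of two such steps. Among the compounds shown here, this does not show which difference between the two cores is responsible, and with only one measured pair on each core, it does not show how either result would hold up across further pairs.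

The compounds shown leave open whether chloro or methoxy in place of the fluoro would also behave differently on the two cores. They also leave open whether a longer chain between the shared core and the 4-fluorophenyl group would bring back the gain seen with compound 2.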